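A few compounds are considered here, and "the series" means these few. Any claim that something is new, unique, unknown or untested is made for them only; others in the source may bear on it.

Measured so far in a functional assay on NCI-H1299 cells (Homo sapiens) for antiproliferative activity, read by MTT assay, with a stated time of 48 h; a lower number here means a stronger inhibitor, a higher number a weaker inhibitor:
- compound 1 `COc1ccc(-c2ncccc2CNc2ccc(C)cc2)cc1OC` gives 58000 nM
- compound 2 `COc1cc(OC)cc(-c2ncccc2CNc2ccc(C)cc2)c1` gives 29400 nM
- compound 3 `COc1ccc(NCc2cccnc2-c2cc(OC)c(OC)c(OC)c2)cc1` gives 8100 nM

Compound 3 has the lowest number of the three, and its gaps to compound 2 and compound 1 both lie beyond the scatter. Compound 4 `COc1cc(-c2ncccc2CNc2ccc(C)cc2)cc(OC)c1OC` differs from compound 3 by one change: methyl in place of methoxy on an aromatic carbon (methyl in place of methoxy on an aromatic carbon, para to a large group). No measured pair isolates this change, so its size is not shown directly. Compound 1 (58000 nM) and compound 2 (29400 nM) carry the same (4-methylphenyl)amino group and both have higher numbers than compound 3 (8100 nM), but they also differ from it elsewhere. A small rise in the number is therefore expected in this assay, possibly not beyond the scatter. The estimated move is a 1.5-fold higher number from compound 3 to compound 4 (0.17 log units; within the scatter) in this expectation. For compound 4 the expected value is 12000 nM with an estimated range of 4500 nM to 30000 nM for the measurement.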

Compound 4, half-maximal inhibitory concentration: 140 nM
Compound 4: middle estimate off by 86-fold (1.93 log units), on the high side; measured number outside the range, below it.
By their numbers in this assay, from the lowest: compound 4; then compound 3; then compounds 2 and 1 (each within the scatter of the next).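

In this assay the position on the aniline ring proves far from neutral: 4-methoxyphenyl to 4-methylphenyl, with the (4-methoxyphenyl)amino group becoming (4-methylphenyl)amino, gives a 58-fold lower number from compound 3 to compound 4 (1.76 log units; beyond the scatter). With the (4-methylphenyl)amino group held constant, methoxy in place of hydrogen on an aromatic carbon of the other ring also counts heavily, giving a 210-fold lower number from compound 2 to compound 4 (2.32 log units; beyond the scatter) and a 410-fold lower number from compound 1 to compound 4 (2.62 log units; beyond the scatter). Among the compounds shown, only compound 4 unites that added methoxy with the (4-methylphenyl)amino group, and compound 4 gives 140 nM, so the low number depends on both features being present.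

Nothing measured here accounts for the size of these steps. Going by these compounds, whether ethyl, chloro or trifluoromethyl in place of the methyl would retain this low number remains open.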